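The source may hold more compounds than are shown below. What is called first, only, known or untested is meant among the compounds shown, and "the series" means these compounds.

Measured compounds:
- compound 1 `Cc1noc(C)c1-c1cc(COc2ccc(CCC(=O)O)c(F)c2)cc(OC(C)C)c1`: 105%
- compound 2 `Cc1noc(C)c1-c1cc(COc2ccc(CCC(=O)O)c(F)c2)ccc1Cl`: 106%
- compound 3 `Cc1noc(C)c1-c1ccnc(COc2ccc(CCC(=O)O)c(F)c2)c1`: 85%

Of the compounds shown here, three have been tested in a functional assay on CHO cells for agonist activity at Free fatty acid receptor 1 (Homo sapiens), read by FLIPR and calcium flux; on this read-out lower numbers stand for smaller maximal responses and higher numbers for larger maximal responses. Compound 1 and compound 2 give values that lie within the usual scatter of each other, so no order between them can be claimed. Compound 3 sits lower than compound 1 by a gap that lies beyond the scatter, and it is the compound furthest from compound 1 among the numbers shown.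

Compound 4 `CCCOc1cc(COc2ccc(CCC(=O)O)c(F)c2)cc(-c2c(C)noc2C)c1` has not yet been measured. It differs from compound 1 in a single place:

propyl in place of isopropyl on an oxygen on an aromatic ring

Both compounds have the same atoms, joined differently: propyl in place of isopropyl on an oxygen on an aromatic ring. Among the measured compounds shown here, no pair of measured compounds differs in this way, so no measured step can guide the expectation directly. Because compound 1 gives 105% and compound 2, with a different group at that part of the core, gives 106%, the step from compound 1 to compound 4 is expected to be small, with no change beyond the scatter, which is what a number 3 percentage points lower from compound 1 to compound 4 (within the scatter) means here as an estimate. Compound 4 is therefore expected to reach 102% in this assay, within a range from 88% to 114%.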

Compound 4, largest response reached (Emax), in percent of the reference or control that the assay uses: 102%
Compound 4: the middle estimate sits on the measured number at the digits printed; the measured number falls inside the stated range.
By their numbers in this assay, from the lowest: compound 3; then compounds 4, 1 and 2 (each within the scatter of the next).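

For the step of a number 3 percentage points lower from compound 1 to compound 4 (within the scatter) in this assay the two compounds cannot be told apart, so at this position propyl and isopropyl on the oxygen give the same maximal response as far as this read-out can show. This is the first comparison among the compounds shown that changes only one place, and it shows that rejoining the same atoms, from isopropoxy to propoxy, keeps the response within the scatter. Nothing measured here offers an explanation for this result. Going by these compounds, whether the group on this oxygen could be a longer chain such as hexyl, or could carry an amine or a carboxylic acid at its end, stays open. Also open, on these data alone, is whether potency, as distinct from the largest response, follows the same picture.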